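Benzyloxy extension at the ether carbon: expectation for compound 3

This account rests on a few compounds, and the source may have more. Where it says the series, first, only, none or still open, it means among the compounds named here.

Compound 2 `COc1ccc2c(=O)c(-c3cc(OC)c(OC)cc3OC)coc2c1` gives 9400 nM in a functional assay on U-251 cells (Homo sapiens) for antiproliferative activity, read by MTT assay, with a stated time of 24 h; on this read-out lower numbers stand for stronger inhibition and higher numbers for weaker inhibition. Among the compounds with values here, of the two numbers so far it is the highest, but its only neighbour, compound 1 `C#CCOc1ccc2c(=O)c(-c3cc(OC)c(OC)cc3OC)coc2c1`, gives 6450 nM in this assay, and the step of a 1.5-fold higher number from compound 1 to compound 2 (0.16 log units; within the scatter) lies within the scatter, so the two cannot be ordered. Compound 3 `COc1cc(OC)c(-c2coc3cc(OCc4cccc(Cl)c4)ccc3c2=O)cc1OC` is not yet measured; it differs from compound 2 by 3-chlorophenyl in place of hydrogen on a saturated chain carbon bound to an oxygen on an aromatic ring. Within the data shown here, the only measured step at this place, a 1.5-fold higher number from compound 1 to compound 2 (0.16 log units; within the scatter), shows that a change on that carbon left the number where it was; no measured step introduces a ring there, so direct guidance is lacking. Compound 3 is therefore expected to land close to compound 2, with the step of a 1.6-fold lower number from compound 2 to compound 3 (0.19 log units; within the scatter) as the working estimate. The estimate for compound 3 is 6000 nM, with a wide range from 1500 nM to 20000 nM.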

Compound 3, half-maximal inhibitory concentration: > 10000 nM
Compound 3 gave a limit, no number; the forecaster's own chance of this, stated with the estimate: 5%; at least 1.6-fold (0.22 log units) between middle value and limit.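

Compound 3 reads > 10000 nM in this assay, which is a limit of the assay and not a number. Within the data shown here, this is the first reading with a ring on the saturated chain carbon bound to an oxygen on an aromatic ring, and the steps, an at least 1.0-fold higher number from compound 2 to compound 3 (0.02 log units; that floor lies within the scatter) and an at least 1.5-fold higher number from compound 1 to compound 3 (0.19 log units; that floor lies within the scatter), show no readable gain from 3-chlorophenyl over hydrogen or ethynyl at this place. Both steps are floors only, so the true size of the change remains unknown, and the reading is bounded on one side alone: the limit of > 10000 nM in this assay, at which 1 of the 3 values shown sits.

Still open, on these data alone, is whether unsubstituted phenyl, a longer chain or an amine on this carbon gives a readable number, and whether the chlorine of the 3-chlorophenyl group matters at all. Also open, as far as these compounds go, is how far compound 3 truly lies from compound 2, since these floors allow anything from no real change to a large loss.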